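A few compounds are considered here, and "the series" means these few. Any claim that something is new, unique, unknown or untested is made for them only; others in the source may bear on it.

Compound 1 `O=C(CC(CC(=O)NC1Cc2ccccc2C1)c1ccc(Cl)cc1)NCCN1CCCCC1` is measured in a functional assay on A549 cells (Homo sapiens) for inhibition (on this read-out higher numbers stand for weaker inhibition and lower numbers for stronger inhibition), where compound 1 gives 28000 nM. Compound 2 `O=C(CC(CC(=O)NC1Cc2ccccc2C1)c1ccccc1)NCCN1CCCCC1` differs from it in one place, (hydrogen in place of chloro on an aromatic carbon). For compound 2 this assay reports only a limit, > 100000 nM. The step of an at least 3.5-fold higher number from compound 1 to compound 2 (0.55 log units; beyond the scatter) therefore reads as a weakening of inhibition, and its size is bounded by the limit of > 100000 nM in this assay, at which 1 of the 3 values shown sits.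

Compound 3 `CCNCCNC(=O)CC(CC(=O)N(CC)C1Cc2ccccc2C1)c1ccc(Cl)cc1` has a core that differs from that of compound 1 in several places at once; how the two cores differ is not broken down here. In this assay compound 3 gives 19400 nM, which sits close to the value of compound 1, within the scatter of the measurement.

Compound 4 `CCNCCNC(=O)CC(CC(=O)N(CC)C1Cc2ccccc2C1)c1ccccc1` is not yet measured. It differs from compound 3 by hydrogen in place of chloro on an aromatic carbon, and the place of this change is the same as in the pair of compound 1 and compound 2, so it is the same change made on a second core. From compound 3 to compound 4 a step of a 3.6-fold higher number from compound 3 to compound 4 (0.56 log units; beyond the scatter) is expected, resting on the measured step of an at least 3.5-fold higher number from compound 1 to compound 2 (0.55 log units; beyond the scatter). On that basis compound 4 is estimated at 70000 nM, with a range from 25000 nM to 150000 nM.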

Compound 4, half-maximal inhibitory concentration: > 100000 nM
Compound 4: only a limit was reported (the forecaster's own chance of this, stated with the estimate: 40%); middle value at least 1.4-fold (0.15 log units) away from the limit.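

Taking away the chloro, so that 4-chlorophenyl becomes phenyl, weakens inhibition on both cores in this assay, and the new step is an at least 5.1-fold higher number from compound 3 to compound 4 (0.71 log units; beyond the scatter). The direction of the change therefore carries over from the core of compound 1 to the core of compound 3, and that agreement in direction is all the two pairs establish: the same change on two cores in this assay, an at least 3.5-fold higher number (0.55 log units; beyond the scatter) from compound 1 to compound 2 and an at least 5.1-fold higher number (0.71 log units; beyond the scatter) from compound 3 to compound 4; the limit leaves it open whether they differ. They do not show the true size of either step, since compound 2 and compound 4 each give only a limit and not a number: the limit of > 100000 nM in this assay, at which 2 of the 4 values shown sit.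

The compounds shown carry only chloro or hydrogen at this place on the ring, so it remains open how a fluoro, methyl or methoxy group there would read in this assay. Going by these compounds, it also remains open whether the same change would carry over to a third core, such as one ending in a primary amine or with a longer chain.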